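Fluoro for Chloro, Repeated on a Second Core

This account rests on a few compounds, and the source may have more. Where it says the series, first, only, none or still open, it means among the compounds named here.

Of the compounds shown here, three have so far been measured in an assay for binding affinity to CDK8/Cyclin C (Homo sapiens), read by FRET and LanthaScreen, with stated times of 20 min and 2 h, tested at 10 uM; a lower number here means less inhibition, a higher number more inhibition at the concentration tested (going by the name of the read-out). Compound 1 `CCOc1ccc(C(=O)c2cnc3ccc(F)cc3c2N2CCCC2)cc1` gives 50%. Compound 3 `CCOc1ccc(C(=O)c2cnc3ccc(Cl)cc3c2N2CCCC2)cc1` shares the core of compound 1; in this assay compound 3 gives 46%. The step between them, a number 4 percentage points higher from compound 3 to compound 1 (within the scatter), is fluoro in place of chloro on an aromatic carbon and lies within the usual scatter, so the two values are read as alike.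

Compound 2 `Cc1ccc(C)c(OCc2nc(C)c(C(=O)Nc3cccc(Cl)c3)s2)c1` stands on a different core; the difference between the two cores is not broken down here. In this assay compound 2 gives 17.1%, lower than both compound 3 and compound 1 by margins beyond the scatter.

Compound 4 `Cc1ccc(C)c(OCc2nc(C)c(C(=O)Nc3cccc(F)c3)s2)c1` has not yet been measured. It differs from compound 2 by fluoro in place of chloro on an aromatic carbon. This is the same kind of change as that from compound 3 to compound 1, not the same: there the place was on an aromatic carbon of a six-membered aromatic ring of carbon only, part of a fused or bridged system of two rings, meta to a fused ring and para to a fused ring; here it is on an aromatic carbon of a six-membered aromatic ring of carbon only, meta to a large group.

A small step is expected from compound 2 to compound 4, a number 2.9 percentage points higher from compound 2 to compound 4 (within the scatter), because a number 4 percentage points higher from compound 3 to compound 1 (within the scatter) stayed within the scatter. Compound 4 is therefore estimated at 20% in this assay, most likely between 6% and 34%.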

Compound 4, a percentage reported as inhibition, at one concentration (the size of the read-out at that concentration, not a potency): 12.1%
The estimate for compound 4 lay 7.9 percentage points above the measured number; low and high end bracket the measured number.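

In this assay, exchanging 3-chlorophenyl for 3-fluorophenyl gives a number 5 percentage points lower from compound 2 to compound 4 (within the scatter), so on this second core, as on the first, the read-out does not tell the two halogens apart. Set side by side, the two steps show a swap that stays small on both cores, with no difference between the cores that can be told: the same change on two cores in this assay, a number 4 percentage points higher (within the scatter) from compound 3 to compound 1 and a number 5 percentage points lower (within the scatter) from compound 2 to compound 4, 9 percentage points apart, within the scatter of two such steps. This shows only that fluoro and chloro were interchangeable in this read-out at the two places and on the two cores shown; it does not show that the change would stay as small on any further core or at another place on the ring, and the opposite signs of the two steps carry no meaning, since each lies within the scatter.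

The compounds shown leave open what a group other than a halogen would do at these places, for instance an amine, a carboxylic acid, a nitrile or a methoxy group, since only chloro and fluoro appear there. They also leave open whether the two halogens would still read alike as potencies, because each number here is the size of the read-out at a single concentration.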